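The source may hold more compounds than are shown below. What is called first, only, known or untested is meant among the compounds shown, and "the series" means these compounds.

Compound 2 `N#CC1=C(NC(=O)CCC(=O)O)N(c2ccc(S(N)(=O)=O)cc2)C2=C(C(=O)CCC2)C1c1ccc(Cl)cc1Cl` sits level with compound 1 `N#CC1=C(NC(N)=O)N(c2ccc(S(N)(=O)=O)cc2)C2=C(C(=O)CCC2)C1c1ccc(Cl)cc1Cl` in a functional assay on Ehrlich cells (Mus musculus) for cytotoxicity, read by trypan blue exclusion, with a stated time of 2 h, tested at 100 ug/mL; a higher number here means a stronger effect of the compound at the concentration tested, a lower number a weaker effect: compound 1 gives 60%, and compound 2 gives 60%. Within the data shown here, the one measured step, no change at the digits printed from compound 1 to compound 2 (within the scatter), was within the scatter. Compound 3 `N#CC1=C(N2C(=O)CCC2=O)N(c2ccc(S(N)(=O)=O)cc2)C2=C(C(=O)CCC2)C1c1ccc(Cl)cc1Cl` differs from compound 2 by 2,5-dioxopyrrolidin-1-yl in place of ((2-carboxyethyl)carbonyl)amino on a double-bonded ring carbon. Among the measured compounds shown here, no measured step covers a change of this kind, and the single step known is flat, so no change beyond the scatter is expected from compound 2 to compound 3, though the range is kept wide. Compound 3 is estimated at 60% in this assay, between 45% and 75%, a step of no change at the digits printed from compound 2 to compound 3 (within the scatter).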

Compound 3, a percentage reported as activity, at one concentration (the size of the read-out at that concentration, not a potency): 90%
Compound 3: the middle estimate sits 30 percentage points below what was measured; measured number outside the range, above it.
By their numbers in this assay, from the lowest: compounds 1 and 2 (each within the scatter of the next); then compound 3.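

At the double-bonded ring carbon next to the ring nitrogen, the group matters after all: 2,5-dioxopyrrolidin-1-yl gives a number 30 percentage points higher from compound 2 to compound 3 (beyond the scatter) and a number 30 percentage points higher from compound 1 to compound 3 (beyond the scatter) in this assay, whereas the two open groups showed no such separation. Against compound 2, the ring enters as the hydrogen-bond donors leave, and the two changes cannot be separated here. Nothing available explains the rise.

From the compounds shown here alone, whether a six-membered imide, such as piperidine-2,6-dione, or a plain amine at this place would hold the higher number stays open.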